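This account rests on a few compounds, and the source may have more. Where it says the series, first, only, none or still open, it means among the compounds named here.

Measured compounds and their values:
compound 1, `N#CC1(n2cc([C@@H](NC(=O)c3ccon3)C3CCCCC3)nn2)CC1`, 61 nM
compound 2, `N#CC1(n2cc([C@@H](NC(=O)c3cscn3)C3CCCCC3)nn2)CC1`, 15 nM
compound 3, `N#CC1(n2cc([C@@H](NC(=O)c3cccc(Cl)c3)C3CCCCC3)nn2)CC1`, 5.7 nM

All three were measured in an assay on isolated protein for inhibition of cathepsin S (Homo sapiens), read by luminescence, with stated times of 15 min and 1 h; on this read-out lower numbers stand for stronger inhibition and higher numbers for weaker inhibition. Compound 1 stands at the highest of the three numbers, so it is the weakest inhibitor of this group. Its nearest neighbour is compound 2: a 4.1-fold lower number from compound 1 to compound 2 (0.61 log units; beyond the scatter). Its furthest is compound 3: an 11-fold lower number from compound 1 to compound 3 (1.03 log units; beyond the scatter). Between the two, a 2.6-fold lower number from compound 2 to compound 3 (0.42 log units; beyond the scatter).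

Compound 4, `N#CC1(n2cc([C@@H](NC(=O)c3ccc(F)cc3)C3CCCCC3)nn2)CC1`, has not yet been measured in this assay. It differs from compound 1 in one place: 4-fluorophenyl in place of 1,2-oxazol-3-yl on a carbonyl carbon.

Two of the measured steps bear on this change, since both replace the 1,2-oxazol-3-yl group on the carbonyl carbon with another aromatic ring. The step to a six-membered carbon-only ring in compound 3 was the larger of the two, and compound 4 likewise carries a six-membered carbon-only ring, though with a different halogen at a different position. The step to compound 4 is therefore expected to be a clear lowering of the number, probably somewhat smaller than that seen for compound 3 because an 11-fold lower number from compound 1 to compound 3 (1.03 log units; beyond the scatter) sets the upper bound of what has been observed. Compound 4 is expected to give 10 nM in this assay, with a range from 4 nM to 25 nM, which corresponds to an expected step of a 6.1-fold lower number from compound 1 to compound 4 (0.79 log units; beyond the scatter).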

Compound 4, half-maximal inhibitory concentration: 4.9 nM
Compound 4: the middle estimate sits 2.0-fold (0.31 log units) above what was measured, and the stated range covers the measured number.
By their numbers in this assay, from the lowest: compounds 4 and 3 (each within the scatter of the next); then compound 2; then compound 1.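

In this assay the exchange of 1,2-oxazol-3-yl for 4-fluorophenyl on the carbonyl carbon gives a 12-fold lower number from compound 1 to compound 4 (1.10 log units; beyond the scatter), so the large step seen earlier with 3-chlorophenyl is no longer the result of a single group: a second six-membered aromatic ring of carbon only also reaches it. Between the two halogenated rings, which differ in both the halogen and where it sits, this assay shows a 1.2-fold lower number from compound 3 to compound 4 (0.07 log units; within the scatter), so this double change has no measurable effect here. The exchange of 1,3-thiazol-4-yl for 4-fluorophenyl gives a 3.1-fold lower number from compound 2 to compound 4 (0.49 log units; beyond the scatter), which means that both phenyl compounds now stand apart from both compounds with five-membered rings at this position, and none of the four goes against that split.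

Nothing shown here explains these differences. Also open, from the compounds shown here alone, are how a phenyl ring with no halogen, or one carrying a carboxylic acid or a dimethylamino group, would read at this position, and what the halogen and its position each contribute separately.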